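The source may hold more compounds than are shown below. What is called first, only, known or untested is meant among the compounds shown, and "the series" means these compounds.

Compound 2 `COC(=O)CCNC(=O)[C@@H]1O[P@](=O)(OCOC(=O)c2ocnc2C)OCC1(C)C` is the starting point of this step. In an ADME assay on blood (Homo sapiens) for pharmacokinetics (a higher number here means that the compound lasts longer, a lower number that the compound disappears faster), compound 2 gives 0.27 h, the lowest of the three numbers gathered so far, though all three lie within the usual scatter of one another: compound 3 `CCOC(=O)CCNC(=O)[C@@H]1O[P@@](=O)(OCOC(=O)C(C)(C)C)OCC1(C)C` gives 0.28 h, and compound 1 `COC(=O)CCNC(=O)[C@@H]1O[P@@](=O)(OCOC(=O)c2ocnc2C)OCC1(C)C` gives 0.52 h. For the measured compounds named here, the only step between two compounds that differ in one place is a 1.9-fold lower number from compound 1 to compound 2 (0.28 log units; within the scatter), and it rests on (the fact that compounds 1 and 2 differ only in the configuration as drawn), so it carries no information about an exchange of the aromatic ring on the ester.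

Compound 4 `COC(=O)CCNC(=O)[C@@H]1O[P@](=O)(OCOC(=O)c2ccns2)OCC1(C)C` carries 1,2-thiazol-5-yl in place of 4-methyl-1,3-oxazol-5-yl on a carbonyl carbon. Going by the values given here, no measured pair isolates such an exchange of the aromatic ring, and the three numbers measured so far all fall within a narrow band. One therefore expects no step beyond the scatter, the estimated step being a 1.1-fold higher number from compound 2 to compound 4 (0.05 log units; within the scatter). For compound 4 in this assay the expected value is 0.3 h, with a range from 0.15 h to 0.6 h.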

Compound 4, half-life: < 0.16 h
Compound 4 was reported as a limit; the forecaster's own chance of this, stated with the estimate: 5%; middle value at least 1.8-fold (0.27 log units) from the limit.
By their numbers in this assay, from the lowest: compounds 2, 3 and 1 (each within the scatter of the next). At a limit, below all of these: compound 4.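

For the compounds shown here, the exchange of 4-methyl-1,3-oxazol-5-yl for 1,2-thiazol-5-yl on a carbonyl carbon gives the first reading of a change of the aromatic ring at this position, and it comes out as an at least 1.6-fold lower number from compound 2 to compound 4 (0.22 log units; that floor lies within the scatter). In this assay compound 4 gives < 0.16 h, which is a limit and not a number. Only a floor for the step is therefore known, and since that floor lies within the scatter, the change is not shown to go beyond it: the limit of < 0.16 h in this assay, at which 1 of the 4 values shown sits.

Still open, from the compounds shown here alone, is how a 4-methyl-1,2-thiazol-5-yl group or an unsubstituted 1,3-oxazol-5-yl group would read on the same carbonyl carbon, which would separate the methyl group from the ring itself. Also open, going by these compounds, is how 1,2-thiazol-5-yl would read with the phosphorus drawn as in compound 1.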